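The source may hold more compounds than are shown below. What is called first, only, known or untested is meant among the compounds shown, and "the series" means these compounds.

Measured so far:
Compound 1, `O=c1[nH]/c(=N\OCCCc2ccc(Br)cc2)ccn1[C@@H]1O[C@H](COP(=O)(O)OP(=O)(O)OP(=O)(O)O)[C@@H](O)[C@H]1O`: 350 nM
Compound 2, `O=c1[nH]/c(=N\OCCCc2cccc([N+](=O)[O-])c2)ccn1[C@@H]1O[C@H](COP(=O)(O)OP(=O)(O)OP(=O)(O)O)[C@@H](O)[C@H]1O`: 457 nM

For the measured compounds named here, in a functional assay on 1321-N1 cells for agonist activity at P2Y purinoceptor 2 (Homo sapiens), read by scintillation counting and inositol phosphate accumulation (a higher number here means that more compound is needed for the effect, a lower number that less compound is needed), compound 2 holds the higher of the two numbers, though its only neighbour, compound 1, lies close: the step of a 1.3-fold higher number from compound 1 to compound 2 (0.12 log units; within the scatter) is within the scatter. Compound 3, `C#CCCCO/N=c1/ccn([C@@H]2O[C@H](COP(=O)(O)OP(=O)(O)OP(=O)(O)O)[C@@H](O)[C@H]2O)c(=O)[nH]1`, differs from compound 2 by ethynyl in place of 3-nitrophenyl on a saturated chain carbon, three bonds along the chain from an oxygen. Going by the values given here, the single measured step exchanges one aromatic ring for another and says little about removing the ring altogether, so the direction is open. Compound 3 is estimated at 700 nM in this assay, between 200 nM and 3000 nM. The expected step is a 1.5-fold higher number from compound 2 to compound 3 (0.19 log units; within the scatter), with a wide range.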

Compound 3, half-maximal effective concentration: 168 nM
Compound 3: middle estimate off by 4.2-fold (0.62 log units), on the high side, and the stated range ends above it.
By their numbers in this assay, from the lowest: compound 3; then compounds 1 and 2 (each within the scatter of the next).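

In this assay the aromatic ring at this place proves dispensable: ethynyl in place of 3-nitrophenyl gives a 2.7-fold lower number from compound 2 to compound 3 (0.43 log units; beyond the scatter) and ethynyl in place of 4-bromophenyl gives a 2.1-fold lower number from compound 1 to compound 3 (0.32 log units; beyond the scatter) in the same direction. Compounds 1 and 2, within the scatter of each other, thus both stand on the same side of the ringless compound 3. Nothing measured here accounts for this difference. As far as these compounds go, whether a longer chain ending in ethynyl would lower the number further remains open, as does how an amine or a carboxylic acid would fare on this saturated chain carbon.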